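Swapping Chloro for Methyl: an Expected Inhibition Value

This account rests on a few compounds, and the source may have more. Where it says the series, first, only, none or still open, it means among the compounds named here.

The measured compounds and their values:
Compound 1 `Clc1ccc(-c2csc(N/N=C/c3cccs3)n2)cc1` gives 83.2%
Compound 2 `Fc1ccc(-c2csc(N/N=C/c3ccc(Cl)cc3Cl)n2)cc1` gives 90%
Compound 3 `COC(=O)c1cc(-c2csc(N/N=C/c3ccc(Cl)cc3Cl)n2)ccc1OCc1ccccc1` gives 63.5%

In a functional assay, read by spectrophotometry, with a stated time of 15 min, tested at 40 ug/mL (a higher number here means a stronger effect of the compound at the concentration tested, a lower number a weaker effect), compound 1 gives 83.2%, the second highest of the three numbers. Its nearest neighbour is compound 2 with 90%, a number that lies within the scatter of compound 1, so the two cannot be ordered. Its furthest is compound 3 with 63.5%, which lies beyond the scatter below compound 1.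

Compound 4 `Cc1ccc(-c2csc(N/N=C/c3cccs3)n2)cc1` is not yet measured. It differs from compound 1 in one place: methyl in place of chloro on an aromatic carbon. Among the compounds with values here, no two of the measured compounds differ in only one place, so there is no measured step that shows what such a change does in this assay. The change exchanges one single heavy atom for another of the same count, with no ring, no donors, no acceptors and no charge touched. For that reason a small step is expected, likely none beyond the scatter, with a slight lean downward from compound 1 only as a guess.

Compound 4 is therefore estimated at 78% in this assay, with a range from 62% to 90%, and the expected step is a number 5.2 percentage points lower from compound 1 to compound 4 (within the scatter).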

Compound 4, a percentage reported as inhibition, at one concentration (the size of the read-out at that concentration, not a potency): 82.8%
Compound 4: middle estimate off by 4.8 percentage points, on the low side; the measured number falls inside the stated range.
By their numbers in this assay, from the lowest: compound 3; then compounds 4, 1 and 2 (each within the scatter of the next).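

In this assay, the exchange of chloro for methyl on an aromatic carbon, para to a large group, gives the only step shown between two compounds that differ in one place: a number 0.4 percentage points lower from compound 1 to compound 4 (within the scatter). At this place on the six-membered aromatic ring of carbon only, the read-out therefore does not separate chloro from methyl, and compound 1 and compound 4 cannot be ordered. Nothing measured alongside these compounds offers an explanation for this result.

The compounds shown leave open what a different kind of group would do at this same place, such as an amine, a carboxylic acid or a longer chain like propyl, since chloro and methyl are the only two groups compared here. Within the data shown here, they also leave open whether methyl in place of chloro would give a step of similar size with something other than the thiophene-bearing remainder of compound 1, as this single pair is the only evidence for the change.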